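The source may hold more compounds than are shown below. What is called first, only, known or untested is meant among the compounds shown, and "the series" means these compounds.

Compound 3 `CCCn1c(=O)[nH]c2nc(-c3ccc(S(=O)(=O)N4CCN(Cc5ccc(Br)cc5)CC4)cc3)[nH]c2c1=O` carries a 4-bromobenzyl group on an amine nitrogen in a ring of the shared core. In an assay on CHO cells for displacement of a labelled ligand from adenosine receptor A1 (Homo sapiens), read by scintillation counting, with a stated time of 90 min, in the presence of a further agent that is not named here (on this read-out lower numbers stand for stronger inhibition and higher numbers for weaker inhibition), compound 3 gives > 1000 nM, which is a limit of the assay rather than a number. Compound 2 `CCCn1c(=O)[nH]c2nc(-c3ccc(S(=O)(=O)N4CCN(C)CC4)cc3)[nH]c2c1=O`, with hydrogen in that place, gives 334 nM. Compound 1 `CCCn1c(=O)c2[nH]c(-c3ccc(S(=O)(=O)N4CCN(c5ccc(Cl)cc5)CC4)cc3)nc2n(CC)c1=O`, with 4-chlorophenyl on the amine nitrogen in a ring, gives > 1000 nM, also a limit. Compound 4 `CCCn1c(=O)[nH]c2nc(-c3ccc(S(=O)(=O)N4CCN(c5cccc(F)c5)CC4)cc3)[nH]c2c1=O` differs from compound 3 by 3-fluorophenyl in place of 4-bromobenzyl on an amine nitrogen in a ring. Going by the values given here, the only measured step that bears on this change is an at least 2.9-fold higher number from compound 2 to compound 3 (0.47 log units; beyond the scatter), and the limit of > 1000 nM in this assay, at which 2 of the 3 values shown sit, shows how often the limit is reached. Compound 4 is therefore expected to remain weak, near 2000 nM with a range of 700 nM to 6000 nM, an expected step that the limit leaves unreadable from compound 3 to compound 4 of no clear size.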

Compound 4, inhibition constant: > 1000 nM
Compound 4 ended at the assay's limit (the forecaster's own chance of this, stated with the estimate: 65%); the middle value does not contradict the limit.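

Replacing methyl with 3-fluorophenyl on this amine nitrogen in a ring gives an at least 2.9-fold higher number from compound 2 to compound 4 (0.47 log units; beyond the scatter) in this assay, so among the compounds shown, the weaker result does not depend on the carbon that links the ring in 4-bromobenzyl. The step between compound 3 and compound 4 cannot be read, since both values are limits and the assay often reaches this one: the limit of > 1000 nM in this assay, at which 3 of the 4 values shown sit.

On these data alone, how much weaker either aromatic group makes the result stays unknown. As far as these compounds go, it also remains open how a group sized between methyl and these rings, such as an ethyl or propyl chain, or a group carrying a carboxylic acid, would behave on this nitrogen.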